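The source may report more compounds than this note shows. Statements on the series, on what has been measured and on what is new or still open speak of the compounds shown alone.

Compound 1, with the structure `O=C(CCc1ccccc1)Nc1nc2ccccc2c(=O)s1`, is the point of departure for this comparison. For the measured compounds named here, in an assay on CHO cells for displacement of a labelled ligand from adenosine receptor A1 (Homo sapiens), read by scintillation counting, with a stated time of 90 min (on this read-out lower numbers stand for stronger inhibition and higher numbers for weaker inhibition), compound 1 gives 1050 nM, and this is the only single number among the three results in hand, so compound 1 stands alone as a measured figure rather than at one end of a ranked series. Compound 2, `Cc1sc2nc(NC(=O)CCCc3ccccc3)sc(=O)c2c1C`, carries no result in this assay: "not determined" (no result reported). Compound 3, `COc1cccc(/C=C/C(=O)Nc2nc3ccccc3c(=O)s2)c1`, reaches only a limit of this assay, > 10000 nM. That limit is the one described by the limit of > 10000 nM in this assay, at which 1 of the 3 values shown sits. The unmeasured compound 4, `O=C(CCCc1ccccc1)Nc1nc2ccccc2c(=O)s1`, differs from compound 1 in one place: benzyl in place of phenyl on a saturated chain carbon, two bonds along the chain from a carbonyl carbon. Going by the values given here, no pair of measured compounds differs in a single place, so no measured step sets the size of this change, and the expectation rests on compound 1 alone. The expected step is a 1.4-fold higher number from compound 1 to compound 4 (0.15 log units; within the scatter), a shift judged to lie within the usual scatter rather than a clear gain or loss. Compound 4 is therefore estimated at 1500 nM, with a range from 400 nM to 6000 nM.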

Compound 4, inhibition constant: 2500 nM
Compound 4: middle estimate off by 1.7-fold (0.22 log units), on the low side; measured number inside the range.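

In this assay, for the compounds shown here, benzyl in place of phenyl on a saturated chain carbon, two bonds along the chain from a carbonyl carbon, gives a 2.4-fold higher number from compound 1 to compound 4 (0.38 log units; beyond the scatter) as the first measured step in this set. It shows that inhibition at this position responds to the change from phenyl to benzyl, and that the response is a modest weakening that lies beyond the usual scatter. Nothing given here accounts for the size or direction of this step.

The compounds shown leave open whether a longer chain would extend this weakening, and whether an amine or a carboxylic acid at the end of the chain would be accepted in this assay. A single step also cannot tell whether the same change would have the same size on another core.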